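Swapping Cyclohexylamino for Butoxy: Cytotoxicity Expected to Stay Low

The source may report more compounds than this note shows. Statements on the series, on what has been measured and on what is new or still open speak of the compounds shown alone.

Two measured compounds share a purine-like core carrying a cyclopropene-bearing diol arm. Compound 1 is `CCCSc1nc(N)nc2c1ncn2/C=C1/CC1(CO)CO`. In an ADME assay on CCRF-HSB-2 cells (Homo sapiens) for cytotoxicity, with a stated time of 7 days (a higher number here means that more compound is tolerated, a lower number that less compound is tolerated), compound 1 gives 98000 nM, a high value meaning that a great deal of compound is tolerated. Compound 2 is `Nc1nc(NC2CCCCC2)c2ncn(/C=C3/CC3(CO)CO)c2n1`, in which cyclohexylamino has replaced propylsulfanyl on an aromatic carbon. For compound 2 this assay reports only a limit, > 20000 nM. The step that the limit leaves unreadable from compound 1 to compound 2 therefore cannot be sized, because of the limit of > 20000 nM in this assay, at which 1 of the 2 values shown sits.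

Compound 3 is `CCCCOc1nc(N)nc2c1ncn2/C=C1/CC1(CO)CO`, not yet measured. It differs from compound 2 as follows: butoxy in place of cyclohexylamino on an aromatic carbon. For the measured compounds named here, the only measured step touching this position is the unreadable one from compound 1 to compound 2, so no sized step bears on the change. What remains is that both measured compounds tolerate a lot of compound, and compound 3 carries a short chain through a heteroatom, as compound 1 does. Compound 3 is therefore estimated at 80000 nM, within 20000 nM to 300000 nM. The expected step that the limit leaves unreadable from compound 2 to compound 3 may well be hidden by the limit again, as a value for compound 2 exists only as a limit.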

Compound 3, half-maximal cytotoxic concentration: > 20000 nM
Compound 3 gave a limit, no number; the forecaster's own chance of this, stated with the estimate: 45%; the middle value does not contradict the limit.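

Compound 3, like compound 2, gives only a limit and no number in this assay, so no step among compound 1, compound 2 and compound 3 can be read: the limit of > 20000 nM in this assay, at which 2 of the 3 values shown sit.

The compounds shown leave open how much of compound 2 or compound 3 the cells actually tolerate, and whether either truly differs from compound 1.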